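The compounds below may be only part of what the source reports. "The series", "measured", "known", "first", "only" and "open" are said of these compounds alone.

Measured compounds:
- compound 1, `CCN(CC)Cc1cc(-c2ccc(Cl)cc2)n(Nc2ccnc3cc(Cl)ccc23)c1C`, in an ADME assay on WEHI13 cells (Mus musculus) for cytotoxicity, read by MTT assay, with a stated time of 72 h; a lower number here means that less compound is tolerated, a higher number that more compound is tolerated: 1450 nM
- compound 2, `CCN(CC)Cc1cc(-c2ccc(F)cc2)n(Nc2ccnc3cc(Cl)ccc23)c1C`, in this assay: 3020 nM
- compound 3, `Cc1c(CN2CCCC2)cc(-c2ccc(F)cc2)n1Nc1ccnc2cc(Cl)ccc12`, in this assay: 2710 nM

Compound 3 sits within the usual scatter of compound 2 and also within the scatter of compound 1, so its number is not separated from either of them. The step to compound 4, `Cc1ccc(-c2cc(CN3CCCC3)c(C)n2Nc2ccnc3cc(Cl)ccc23)cc1`, is methyl in place of fluoro on an aromatic carbon. Going by the values given here, the only measured step at this same aromatic carbon is a 2.1-fold higher number from compound 1 to compound 2 (0.32 log units; beyond the scatter), a modest change beyond the scatter; the other measured step, a 1.1-fold lower number from compound 2 to compound 3 (0.05 log units; within the scatter), concerns the saturated chain carbon and is within the scatter, so it says little here. Taken together, an exchange at this aromatic carbon has so far moved the number by a modest amount, and compound 4 is therefore expected to show at most a modest step, a 1.4-fold lower number from compound 3 to compound 4 (0.15 log units; within the scatter), which may also fall within the scatter. For compound 4 the estimated value in this assay is 1900 nM, with a range from 950 nM to 3800 nM.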

Compound 4, half-maximal cytotoxic concentration: 4480 nM
For compound 4 the middle estimate is 2.4-fold (0.37 log units) below the measured one; measured number outside the range, above it.
By their numbers in this assay, from the lowest: compounds 1, 3, 2 and 4 (each within the scatter of the next, the first and the last beyond it).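

In this assay, methyl in place of fluoro gives a 1.7-fold higher number from compound 3 to compound 4 (0.22 log units; within the scatter) and so does not separate the two compounds, even though a halogen gives way to a carbon group at this aromatic carbon. The earlier step at this carbon, a 2.1-fold higher number from compound 1 to compound 2 (0.32 log units; beyond the scatter), was an exchange between two halogens with diethylamino on the side chain, whereas the new step carries pyrrolidin-1-yl there. Exchanges at this carbon therefore do not all give a step beyond the scatter, and no available evidence accounts for either step.

Going by these compounds, whether the chloro and methyl groups would differ on the same pyrrolidin-1-yl side chain remains open. Also open, on these data alone, is how an amine, a carboxylic acid or a longer chain at this aromatic carbon would read against the methyl group.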